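Ester variation on the shared core: plasma stability notes

This account rests on a few compounds, and the source may have more. Where it says the series, first, only, none or still open, it means among the compounds named here.

Within the data shown here, in an ADME assay on a cell-free system (plasma, Homo sapiens) for metabolic stability, with Plasma (Rattus norvegicus) as the target, read by HPLC, at pH 7.4 (a higher number here means that the compound lasts longer, a lower number that the compound disappears faster), compound 3 `COc1cccc(C(=O)O[C@@H]2CO[C@H]3[C@@H]2OC[C@@H]3OC(=O)c2ccccc2OC(C)=O)c1` gives 0.0525 h and stands second highest of the three numbers so far. Compound 2 `CC(=O)Oc1ccccc1C(=O)O[C@H]1CO[C@H]2[C@@H]1OC[C@H]2OC(C)=O` gives 0.0608 h; the two sit within the scatter of each other, as the step of a 1.2-fold lower number from compound 2 to compound 3 (0.06 log units; within the scatter) shows. Compound 1 `CC(=O)Oc1ccccc1C(=O)O[C@H]1CO[C@H]2[C@@H]1OC[C@H]2OC(=O)c1ccc(O)cc1` gives 0.0198 h, the lowest of the three, and the step of a 2.7-fold higher number from compound 1 to compound 3 (0.42 log units; beyond the scatter) is beyond the scatter.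

Compound 4 `CC(=O)Oc1ccccc1C(=O)O[C@H]1CO[C@H]2[C@@H]1OC[C@H]2OC(=O)c1ccc(-c2ccccc2)cc1` differs from compound 3 only at the carbonyl carbon already varied in this series: 4-phenylphenyl in place of 3-methoxyphenyl on a carbonyl carbon. Among the measured compounds shown here, three measured steps bear on this position. The move from 4-hydroxyphenyl to methyl, a 3.1-fold higher number from compound 1 to compound 2 (0.49 log units; beyond the scatter), was a modest gain, as was the move to 3-methoxyphenyl; the swap between methyl and 3-methoxyphenyl stayed within the scatter. 4-Phenylphenyl, like methyl and 3-methoxyphenyl, carries no hydroxyl, and the expected step in this assay is within the scatter, in no clear direction. Compound 4 is therefore estimated at 0.055 h (range 0.025 h to 0.12 h), which means an expected step of a 1.0-fold higher number from compound 3 to compound 4 (0.02 log units; within the scatter).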

Compound 4, half-life: > 0.333 h
Compound 4: only a limit was reported; the forecaster's own chance of this, stated with the estimate: 5%; at least 6.0-fold (0.78 log units) between middle value and limit.
By their numbers in this assay, from the lowest: compound 1; then compounds 3 and 2 (each within the scatter of the next). At a limit, above all of these: compound 4.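

At this carbonyl carbon, methyl and 3-methoxyphenyl stayed within the scatter of each other, whereas 4-phenylphenyl, with its two six-membered aromatic rings, gives a step beyond the scatter from both (an at least 6.3-fold higher number from compound 3 to compound 4 (0.80 log units; beyond the scatter); an at least 5.4-fold higher number from compound 2 to compound 4 (0.73 log units; beyond the scatter)). The step from the hydroxy-bearing compound is larger still (an at least 16-fold higher number from compound 1 to compound 4 (1.22 log units; beyond the scatter)), yet compound 2, compound 3 and compound 4 all lack that hydroxy group and do not sit together, so its absence alone does not set the number. Compound 4 carries only a limit in this assay: the limit of > 0.333 h in this assay, at which 1 of the 4 values shown sits.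

Going by these compounds, how far compound 4 lies past its limit remains unknown, so these steps have no upper end. Also open, on these data alone, is whether a single phenyl, a longer alkyl chain or a phenyl bearing an amine or a carboxylic acid at this carbonyl carbon would behave like 4-phenylphenyl.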